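Swapping the Phenylethynyl Arm for a Chlorophenyl Ring

This account rests on a few compounds, and the source may have more. Where it says the series, first, only, none or still open, it means among the compounds named here.

Compound 1 (`Nc1ncnn2c([C@@H]3O[C@H](CO)[C@@H](O)[C@H]3O)cc(C#Cc3ccccc3)c12`) is the starting point. In a functional assay on NCI-H460 cells (Homo sapiens) for antiproliferative activity, with a stated time of 72 h (a higher number here means a weaker inhibitor, a lower number a stronger inhibitor), compound 1 gives 38500 nM, the highest of the two plain numbers here. Compound 3 (`Nc1ncnn2c([C@@H]3O[C@H](CO)[C@@H](O)[C@H]3O)cc(/C=C/c3ccccc3)c12`) gives 3700 nM in this assay, and the step of a 10-fold lower number from compound 1 to compound 3 (1.02 log units; beyond the scatter) is large. Compound 2 (`Nc1ncnn2c([C@@H]3O[C@H](CO)[C@@H](O)[C@H]3O)cc(-c3ccccc3F)c12`) is reported in this assay only as a limit, > 100000 nM, which means it sits at the limit of > 100000 nM in this assay, at which 1 of the 3 values shown sits. The step of an at least 2.5-fold higher number from compound 1 to compound 2 (0.41 log units; beyond the scatter) is therefore known only as a lower bound.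

Compound 4 (`Nc1ncnn2c([C@@H]3O[C@H](CO)[C@@H](O)[C@H]3O)cc(-c3ccccc3Cl)c12`) is not yet measured. Relative to compound 1, the change is 2-chlorophenyl in place of 2-phenylethynyl on an aromatic carbon. The closest measured comparison is the step from compound 1 to compound 2, where the same 2-phenylethynyl group left and 2-fluorophenyl entered, giving a number at least modestly higher. On that basis a higher number is expected for compound 4, beyond the scatter, with a real chance that only a limit is reported. The expected step is a 2.3-fold higher number from compound 1 to compound 4 (0.37 log units; beyond the scatter). The estimate for compound 4 in this assay is 90000 nM, ranging from 30000 nM to 300000 nM.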

Compound 4, half-maximal inhibitory concentration: > 100000 nM
Compound 4 ended at the assay's limit (the forecaster's own chance of this, stated with the estimate: 50%); middle value at least 1.1-fold (0.04 log units) from the limit.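

Compound 4 is reported in this assay only as a limit, and it shares that limit with compound 2: the limit of > 100000 nM in this assay, at which 2 of the 4 values shown sit.

Across these four compounds, the two with a halogen-bearing phenyl ring attached directly to this carbon both end at the limit, while the two with a two-carbon link to the phenyl ring give plain numbers. The 2-chlorophenyl group gives an at least 2.5-fold higher number from compound 1 to compound 4 (0.41 log units; beyond the scatter) and an at least 27-fold higher number from compound 3 to compound 4 (1.43 log units; beyond the scatter), so a second halogen-bearing ring now shows the same loss, and both steps are lower bounds. The step between compound 2 and compound 4 cannot be read, so chloro and fluoro cannot be ranked.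

The compounds shown leave open whether the halogen or the direct attachment of the ring matters more, a question that an unsubstituted phenyl group could address. Going by these compounds, how a saturated 2-phenylethyl chain or an amine at this position would behave also remains open.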